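Hydroxy to chloro on the amide side chain

The source may hold more compounds than are shown below. What is called first, only, known or untested is meant among the compounds shown, and "the series" means these compounds.

Measured so far in a functional assay on KYSE-450 cells (Homo sapiens) for inhibition, read by MTT assay, with a stated time of 48 h (on this read-out higher numbers stand for weaker inhibition and lower numbers for stronger inhibition), are:
compound 1 `CCCCC(=O)N(Cc1ccc(OC)c(O)c1)c1cc(OC)c(OC)c(OC)c1` with 300 nM
compound 2 `COc1ccc(CN(C(=O)CO)c2cc(OC)c(OC)c(OC)c2)cc1O` with 370 nM

Compound 2 gives 370 nM and sits within the scatter of compound 1, so the two values cannot be ranked. Compound 3 `COc1ccc(CN(C(=O)CCl)c2cc(OC)c(OC)c(OC)c2)cc1O` is the next to be read. It carries chloro in place of hydroxy on a saturated chain carbon bound to a carbonyl carbon.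

Among the compounds with values here, only one measured step bears on this place (a 1.2-fold higher number from compound 1 to compound 2 (0.09 log units; within the scatter)). There, hydroxy replaced propyl on the same chain carbon and this assay did not move beyond the scatter. Within the data shown here, no chloro compound has been measured here, and a single step is thin evidence, so the expectation stays loose. No shift beyond the scatter is expected in either direction.

The expected step is a 1.2-fold lower number from compound 2 to compound 3 (0.09 log units; within the scatter) (a call resting on that single step). Compound 3 is estimated at 300 nM with an expected range of 100 nM to 900 nM (kept wide for that reason).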

Compound 3, half-maximal inhibitory concentration: 210 nM
Estimate against measurement, compound 3: 1.4-fold (0.15 log units) above; the range from low to high includes it.
By their numbers in this assay, from the lowest: compounds 3, 1 and 2 (each within the scatter of the next).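

In this assay, the saturated chain carbon bound to a carbonyl carbon has now carried propyl, hydroxy and chloro without any step leaving the scatter. Chloro cannot be ranked against hydroxy, with a 1.8-fold lower number from compound 2 to compound 3 (0.25 log units; within the scatter), or against propyl, with a 1.4-fold lower number from compound 1 to compound 3 (0.15 log units; within the scatter), so the three compounds form one unresolved group rather than an order. The change from compound 2 to compound 3 also replaces a group with 1 hydrogen-bond donor and 1 hydrogen-bond acceptor by one with neither, and for this pair that difference in counts comes with no step beyond the scatter. No measured evidence is at hand to account for these numbers.

As far as these compounds go, whether an amine, a carboxylic acid or a longer chain on this same chain carbon would give a step beyond the scatter remains open, so the limits of what this position accepts are unknown. Also open, from the compounds shown here alone, is whether bromo or fluoro would behave like chloro here, and whether the picture seen in this assay would hold in any other read-out.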